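Ortho-substituted purine: exchanging a chloro for an amino group

This account rests on a few compounds, and the source may have more. Where it says the series, first, only, none or still open, it means among the compounds named here.

Measured compounds:
- compound 1, `ClCc1ccccc1Cn1cnc2c(Cl)nc(Cl)nc21`: "not determined" (no result reported)
- compound 2, `ClCc1ccc(Cn2cnc3nc(Cl)nc(Cl)c32)cc1`: 29500 nM

Compound 1 `ClCc1ccccc1Cn1cnc2c(Cl)nc(Cl)nc21` stands on no number at all: in a functional assay on SNB-19 cells (Homo sapiens) for cytotoxicity, read by sulforhodamine B assay, with a stated time of 48 h (a higher number here means a weaker inhibitor of growth, a lower number a stronger inhibitor of growth), compound 1 gives "not determined" (no result reported), so there is nothing to place it against. Among the measured compounds shown here, the only measured point is compound 2 `ClCc1ccc(Cn2cnc3nc(Cl)nc(Cl)c32)cc1`, which in this assay gives 29500 nM, a weak result; no step between compound 1 and compound 2 is defined, so it serves only as a backdrop.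

Compound 3 `Nc1nc(Cl)c2ncn(Cc3ccccc3CCl)c2n1` differs from compound 1 by one change, (amino in place of chloro on an aromatic carbon), amino in place of chloro on an aromatic carbon. For the measured compounds named here, with no measured step to guide it, and only the weak value of compound 2 as context, the expected size of this step in this assay is unknown in direction and is taken as none beyond the scatter. Compound 3 is accordingly expected to give about 50000 nM, in the range 10000 nM to 200000 nM.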

Compound 3, concentration for 50% growth inhibition: 6030 nM
Compound 3: middle estimate off by 8.3-fold (0.92 log units), on the high side; the measured number lies below the stated range.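

In this assay, among the compounds shown here, compound 3 gives 6030 nM while compound 1 gives "not determined" (no result reported) and so no step from compound 1 to compound 3 can be read. Going by these compounds, what amino in place of chloro does to growth inhibition stays open. No supporting data bear on the value of compound 3.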